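Swapping the Chlorophenyl Arm for a Brominated Phenol

A few compounds are considered here, and "the series" means these few. Any claim that something is new, unique, unknown or untested is made for them only; others in the source may bear on it.

Compound 1 `Cn1c(=O)c(=O)n(C2CCCC2)c2nc(N/N=C/c3ccc(Cl)cc3)ncc21` is the starting point. In a functional assay on A549 cells (Homo sapiens) for antiproliferative activity, read by MTT assay (a higher number here means a weaker inhibitor, a lower number a stronger inhibitor), compound 1 gives 6890 nM, the lowest of the two numbers obtained, and its nearest neighbour is compound 2 `Cn1c(=O)c(=O)n(C2CCCC2)c2nc(N/N=C/c3ccc(S(C)(=O)=O)cc3)ncc21`, which in this assay gives 84500 nM. Compound 3 `COc1ccc(/C=N/Nc2ncc3c(n2)n(C2CCCC2)c(=O)c(=O)n3C)c(OC)c1` yields no number at all but only (the limit of > 100000 nM in this assay, at which 1 of the 3 values shown sits), so its result in this assay stands as > 100000 nM.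

Both changes made so far on the chlorophenyl arm of compound 1 weakened it. Putting methylsulfonyl in place of chloro on an aromatic carbon gave a 12-fold higher number from compound 1 to compound 2 (1.09 log units; beyond the scatter). Putting 2,4-dimethoxyphenyl in place of 4-chlorophenyl on a carbon with a double bond to nitrogen gave an at least 14-fold higher number from compound 1 to compound 3 (1.16 log units; beyond the scatter). Between those two, the step was an at least 1.1-fold higher number from compound 2 to compound 3 (0.07 log units; that floor lies within the scatter).

Compound 4 `Cn1c(=O)c(=O)n(C2CCCC2)c2nc(N/N=C/c3ccc(O)c(Br)c3)ncc21` differs from compound 1 by 3-bromo-4-hydroxyphenyl in place of 4-chlorophenyl on a carbon with a double bond to nitrogen. The two measured replacements of that arm each gave a large rise in the number, so a rise beyond the scatter is expected for compound 4 as well, though a bromine remains and the change is smaller than in compound 3, so a step of roughly a 3.6-fold higher number from compound 1 to compound 4 (0.56 log units; beyond the scatter) is expected. In this assay compound 4 is estimated at 25000 nM, within a range from 6000 nM to 90000 nM.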

Compound 4, half-maximal inhibitory concentration: 12800 nM
The estimate for compound 4 lay 2.0-fold (0.29 log units) above the measured number, and the stated range covers the measured number.
By their numbers in this assay, from the lowest: compounds 1 and 4 (each within the scatter of the next); then compound 2. At a limit, above all of these: compound 3.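

This result shows that the arm on the carbon with a double bond to nitrogen can be replaced without a loss beyond the scatter in this assay (a 1.9-fold higher number from compound 1 to compound 4 (0.27 log units; within the scatter)), which neither earlier replacement showed. The identity of the new arm also matters, since 3-bromo-4-hydroxyphenyl separates clearly from both 4-(methylsulfonyl)phenyl (a 6.6-fold lower number from compound 2 to compound 4 (0.82 log units; beyond the scatter)) and 2,4-dimethoxyphenyl (an at least 7.8-fold lower number from compound 3 to compound 4 (0.89 log units; beyond the scatter)), so the loss seen earlier did not follow from removing 4-chlorophenyl alone. The second of those steps gives only a floor, as the result for compound 3 is a limit of the assay and not a number: the limit of > 100000 nM in this assay, at which 1 of the 4 values shown sits.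

The compounds shown leave open how the bromine and the hydroxyl each contribute, as they enter together in compound 4 and no arm here carries just one of them. It also remains open whether a phenyl arm bearing an amine or a carboxylic acid would match compound 1 or give a number lower than it by more than the scatter, since no compound shown here does so.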